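This account rests on a few compounds, and the source may have more. Where it says the series, first, only, none or still open, it means among the compounds named here.

Of the compounds shown here, two of this set have been tested in a functional assay on CWR22R cells (Homo sapiens) for inhibition; a lower number here means a stronger inhibitor, a higher number a weaker inhibitor. Compound 1 `CCn1c(=O)/c(=C2\Sc3ccccc3N2C)s/c1=C\c1ccncc1Nc1ccccc1F` gives 300 nM in this assay. Compound 2 `CCn1c(=O)/c(=C2\Sc3ccc(C)cc3N2C)s/c1=C\c1ccncc1Nc1ccccc1C` gives 480 nM in this assay, the higher of the two numbers, though the gap to compound 1 lies within the usual scatter and so does not separate the two.

Compound 3 `CCn1c(=O)/c(=C2\Sc3ccc(C)cc3N2C)s/c1=C\c1ccncc1Nc1ccccc1F` has not been measured yet. It is built from compound 2 by one change, (fluoro in place of methyl on an aromatic carbon), so the (2-methylphenyl)amino group becomes a (2-fluorophenyl)amino group while the rest of the shared core stays as it is. Among the measured compounds shown here, no pair of measured compounds differs in exactly this way, so there is no measured step to lean on; compound 1 does carry the fluoro group, but it differs from compound 2 in a second place as well, and the two measured values show only that both compounds sit close together. The expected step from compound 2 to compound 3 is therefore small, a 1.3-fold lower number from compound 2 to compound 3 (0.12 log units; within the scatter), and not clearly beyond the scatter in either direction. Compound 3 is expected to give about 360 nM in this assay, with a range from 150 nM to 850 nM.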

Compound 3, half-maximal inhibitory concentration: 150 nM
For compound 3 the middle estimate is 2.4-fold (0.38 log units) above the measured one; measured number inside the range.
By their numbers in this assay, from the lowest: compounds 3, 1 and 2 (each within the scatter of the next, the first and the last beyond it).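

In this assay, among the compounds shown here, putting fluoro in place of methyl on the aromatic carbon ortho to a large group gives a 3.2-fold lower number from compound 2 to compound 3 (0.51 log units; beyond the scatter), the first single-place change in this set to lie beyond the scatter, so this position does respond to swapping one heavy atom for another. The other single-place change, methyl in place of hydrogen on an aromatic carbon of the shared core, gives a 2.0-fold lower number from compound 1 to compound 3 (0.30 log units; within the scatter), which does not separate the two compounds that both carry the (2-fluorophenyl)amino group. Nothing shown here offers an explanation for either step.

From the compounds shown here alone, only fluoro and methyl appear at this position, so it remains open what a chloro group, a methoxy group or a plain hydrogen would give there. For the compounds shown here, it is also open whether the change from methyl to fluoro would have a similar size on the core of compound 1, which lacks the second methyl group, since only one such pair can be read here.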